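Swapping Methyl for Phenyl: Expected Gain in Cell Potency

The compounds below may be only part of what the source reports. "The series", "measured", "known", "first", "only" and "open" are said of these compounds alone.

Three compounds have been measured in a functional assay on SK-BR-3 cells (Homo sapiens) for inhibition, read by sulforhodamine B assay, with a stated time of 48 h; on this read-out higher numbers stand for weaker inhibition and lower numbers for stronger inhibition:

Compound 1 `COc1cc(OC)cc(N2NC3=CC[C@@H](OC)O[C@@]3(c3ccccc3)CC2=O)c1`: 1200 nM
Compound 2 `COc1cc(OC)cc(N2NC3=CC[C@@H](OC)O[C@@]3(C)CC2=O)c1`: 5700 nM
Compound 3 `CO[C@@H]1CC=C2NN(c3cncnc3)C(=O)C[C@]2(C)O1`: 3400 nM

Compound 2 and compound 1 share a core and differ in one place, (phenyl in place of methyl on a saturated ring carbon); that change gave a 4.8-fold lower number from compound 2 to compound 1 (0.68 log units; beyond the scatter). Compound 3 carries a different core; the difference between the two cores is not broken down here. Compound 4, `CO[C@@H]1CC=C2NN(c3cncnc3)C(=O)C[C@]2(c2ccccc2)O1`, has not yet been measured and differs from compound 3 by phenyl in place of methyl on a saturated ring carbon. This is the same kind of change as the earlier one, not the same: in compound 3 the methyl sits on a saturated ring carbon of a six-membered non-aromatic ring with 1 oxygen, next to the ring oxygen, whereas in compound 2 it sits on a six-membered non-aromatic ring with 2 nitrogen. Because the earlier step was a 4.8-fold lower number from compound 2 to compound 1 (0.68 log units; beyond the scatter), a step of similar size, a 4.5-fold lower number from compound 3 to compound 4 (0.66 log units; beyond the scatter), is expected here, with the changed surroundings leaving it less certain. Compound 4 is therefore estimated at 750 nM, between 300 nM and 2000 nM.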

Compound 4, half-maximal inhibitory concentration: 5300 nM
For compound 4 the middle estimate is 7.1-fold (0.85 log units) below the measured one; the measured number lies above the stated range.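

In this assay, phenyl in place of methyl on a saturated ring carbon gave a 1.6-fold higher number from compound 3 to compound 4 (0.19 log units; within the scatter), so the gain seen on the core of compound 2 did not carry over to the core of compound 3. The same change gave different results on the two cores: the same change on two cores in this assay, a 4.8-fold lower number (0.68 log units; beyond the scatter) from compound 2 to compound 1 and a 1.6-fold higher number (0.19 log units; within the scatter) from compound 3 to compound 4, 7.4-fold (0.87 log units) apart, beyond the scatter of two such steps. This shows that the earlier step cannot be transferred from one core to the other as a fixed amount, but two pairs do not show which difference between the cores is responsible or how the change would behave on a further core.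

From the compounds shown here alone, it remains open which part of the core decides the outcome. Going by these compounds, it is also open whether a butyl chain or a carboxylic acid in place of the methyl would lower the number on the core of compound 3.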